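The source may hold more compounds than are shown below. What is called first, only, known or untested is meant among the compounds shown, and "the series" means these compounds.

Measured compounds:

Compound 1 `C[C@@H]1CCCN1c1c(C#N)c2c(N)nc(Nc3ccn(C)n3)cc2n1C` gives 206 nM in an assay on isolated protein for inhibition of Leucine-rich repeat serine/threonine-protein kinase 2 variant G2019S (Homo sapiens), read by TR-FRET and LanthaScreen, with stated times of 50 min and 30 min, in the presence of a further agent that is not named here; on this read-out higher numbers stand for weaker inhibition and lower numbers for stronger inhibition.
Compound 2 `Cc1c(Nc2nc(N)c3c(C#N)c(N4CCC[C@H]4C)n(C)c3n2)cnn1CC(C)(C)O` gives 35 nM in this assay.
Compound 3 `C[C@@H]1CCCN1c1c(C(N)=O)c2c(N)ncnc2n1C` gives 2240 nM in this assay.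

Compound 2 has the lowest number of the three in this assay. Compound 1 stands nearest to it, yet its number is higher by more than the usual scatter of such measurements, and compound 3 stands furthest away, far beyond that scatter. Compound 2 is therefore the most potent of the three measured compounds.

Compound 4 `Cc1c(Nc2nc(N)c3c(C#N)c(N4CCC[C@H]4C)n(C)c3n2)cnn1C` has not yet been measured. It differs from compound 2 in one place: hydrogen in place of 1-hydroxy-1-methylethyl on a saturated chain carbon bound to an aromatic nitrogen. The group that leaves carries one hydrogen-bond donor and one hydrogen-bond acceptor, and only a hydrogen takes its place. Within the data shown here, no step between two measured compounds of this kind is available, so the expectation rests on the standing of compound 2 alone. A modest move toward a higher number is expected, the step expected a 1.9-fold higher number from compound 2 to compound 4 (0.27 log units; within the scatter) possibly no larger than the scatter itself. Compound 4 is estimated to give 65 nM, expected to fall between 20 nM and 200 nM.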

Compound 4, half-maximal inhibitory concentration: 43 nM
Compound 4: the middle estimate sits 1.5-fold (0.18 log units) above what was measured, and the stated range covers the measured number.
By their numbers in this assay, from the lowest: compounds 2 and 4 (each within the scatter of the next); then compound 1; then compound 3.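

In this assay, the exchange of 1-hydroxy-1-methylethyl for hydrogen on the saturated chain carbon bound to an aromatic nitrogen comes to a 1.2-fold higher number from compound 2 to compound 4 (0.09 log units; within the scatter) and so leaves the two compounds indistinguishable on this read-out. Among these compounds, the earlier compounds offered no pair differing in one place, and this step gives the first direct reading of this position: the chain can be cut from 2-hydroxy-2-methylpropyl to methyl, losing the hydrogen-bond donor and acceptor of the leaving group, with the number staying within the scatter. No measurement shown here explains this result.

The compounds shown leave open how an amine, a carboxylic acid or a longer chain would read at this place. They also leave open whether the same exchange would read alike on another core, such as that of compound 1.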